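A few compounds are considered here, and "the series" means these few. Any claim that something is new, unique, unknown or untested is made for them only; others in the source may bear on it.

Compound 2 `O=[N+]([O-])c1ccc(-c2cc(-c3ccccc3-c3ccccc3)n[nH]2)cc1` gives 1200 nM in a functional assay on AGS cells (Homo sapiens) for inhibition, read by MTT assay, with a stated time of 48 h (a higher number here means a weaker inhibitor of growth, a lower number a stronger inhibitor of growth), the lowest of the two numbers measured; the nearest is compound 1 `FC(F)(F)c1ccc(-c2cc(-c3ccccc3-c3ccccc3)n[nH]2)cc1`, which gives 6900 nM. Within the data shown here, the one measured step, a 5.8-fold lower number from compound 1 to compound 2 (0.76 log units; beyond the scatter), shows that changing the group at this position moves the number by a modest amount. Compound 3 `Nc1ccc(-c2cc(-c3ccccc3-c3ccccc3)n[nH]2)cc1` differs from compound 2 by amino in place of nitro on an aromatic carbon. Among the measured compounds shown here, no measured step involves an amino group, so only the size of that step guides the expectation. Compound 3 is therefore expected to land at about 2500 nM, between 700 nM and 9000 nM, meaning an expected step of a 2.1-fold higher number from compound 2 to compound 3 (0.32 log units; beyond the scatter).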

Compound 3, concentration for 50% growth inhibition: 8400 nM
Estimate against measurement, compound 3: 3.4-fold (0.53 log units) below, and the stated range covers the measured number.
By their numbers in this assay, from the lowest: compound 2; then compounds 1 and 3 (each within the scatter of the next).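

In this assay, amino in place of nitro on the aromatic carbon takes away the advantage nitro had shown (a 7.0-fold higher number from compound 2 to compound 3 (0.85 log units; beyond the scatter)). Amino and trifluoromethyl cannot be told apart here (a 1.2-fold higher number from compound 1 to compound 3 (0.09 log units; within the scatter)), so among these three groups nitro alone stands apart, which the first pair could not show. No evidence is available to explain this difference.

The compounds shown leave open whether a nitrile or a carboxylic acid at this position would match nitro. They also leave open whether an acetamide would differ from the free amino group.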